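Methoxy Addition on the Aryl Ring of Compound 1

The compounds below may be only part of what the source reports. "The series", "measured", "known", "first", "only" and "open" are said of these compounds alone.

Compound 1 `COc1ccc(-c2cc(/C=C/C(=O)c3ccc(N)cc3)[nH]n2)cc1` sits at the lower end of the two numbers at hand. In a functional assay on 786-0 cells (Homo sapiens) for cytotoxicity, read by sulforhodamine B assay, with a stated time of 48 h, tested at 100 uM (a lower number here means a stronger effect, a higher number a weaker effect of the compound at the concentration tested), compound 1 gives -57%. Compound 2 `COc1cc(-c2cc(/C=C/C(=O)c3ccc(Cl)c(Cl)c3)[nH]n2)cc(OC)c1OC` in this assay gives -10%, a number higher than that of compound 1 by a margin beyond the usual scatter; the two compounds differ in more than one place, so their values show only that much. Compound 3 `COc1ccc(-c2cc(/C=C/C(=O)c3ccc(N)cc3)[nH]n2)cc1OC` is the untested member of the set. Relative to compound 1, it carries methoxy in place of hydrogen on an aromatic carbon. Among the measured compounds shown here, no pair of measured compounds isolates this single change, and compound 2 at -10% carries its additional methoxy groups alongside other differences, so the effect of this methoxy alone is unknown. A step from compound 1 to compound 3 of modest size toward a weaker effect, or none beyond the scatter, is expected, a number 12 percentage points higher from compound 1 to compound 3 (beyond the scatter). Compound 3 is expected to give about -45% in this assay, within a range from -80% to -5%.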

Compound 3, a percentage reported as activity, at one concentration (the size of the read-out at that concentration, not a potency): -97%
For compound 3 the middle estimate is 52 percentage points above the measured one; the measured number lies below the stated range.
By their numbers in this assay, from the lowest: compound 3; then compound 1; then compound 2.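

In this assay the addition of methoxy in place of hydrogen on an aromatic carbon, ortho to a methoxy group, gives a number 40 percentage points lower from compound 1 to compound 3 (beyond the scatter) and so moves toward a stronger effect at the concentration tested. Among the compounds shown here, this is the first reading of the single change, which the earlier comparison of compounds differing in more than one place could not give, and it shows that this position is not indifferent to substitution. No measurement at hand accounts for the step.

From the compounds shown here alone, whether the step is specific to methoxy remains open, and a hydroxyl group, a fluorine atom or an ethoxy group at the same aromatic carbon would test this. Also open, going by these compounds, is whether it would persist if the amine shared by compound 1 and compound 3 were replaced by a carboxylic acid.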